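Fluoro for chloro on the para-substituted ring

The compounds below may be only part of what the source reports. "The series", "measured", "known", "first", "only" and "open" are said of these compounds alone.

Compound 3 `Cc1ccc(-c2cc(-c3ccc(Cl)cc3)[nH]n2)cc1` gives the lowest number of the three measured in an assay on mitochondria from brain for inhibition of Amine oxidase [flavin-containing] B (Bos taurus), read by fluorescence (on this read-out lower numbers stand for stronger inhibition and higher numbers for weaker inhibition), with compound 3 at 8.91 nM. Compound 1 `Fc1ccc(-c2cc(-c3ccccc3)n[nH]2)cc1` gives 30.2 nM, and compound 2 `Fc1ccc(-c2cc(-c3ccc(Cl)cc3)n[nH]2)cc1` gives 40.7 nM. The one single-point step among these, the change a 1.3-fold higher number from compound 1 to compound 2 (0.13 log units; within the scatter), stays within the scatter, so adding chlorine to that ring did not move the read-out beyond the usual repeat variation.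

Compound 4 `Cc1ccc(-c2cc(-c3ccc(F)cc3)[nH]n2)cc1` differs from compound 3 by one halogen swap: fluoro in place of chloro on an aromatic carbon. Within the data shown here, no measured pair shows fluoro against chloro directly, so the only guidance is the hydrogen-to-chloro comparison between compound 1 and compound 2, which was small. If chloro against hydrogen made no measurable difference on this ring, the smaller change from chloro to fluoro is expected to make no difference beyond the scatter either, in either direction.

Compound 4 is therefore expected to stay close to compound 3, with the estimated step of a 1.2-fold higher number from compound 3 to compound 4 (0.09 log units; within the scatter). In this assay compound 4 is estimated at 11 nM, with a range from 4 nM to 28 nM.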

Compound 4, half-maximal inhibitory concentration: 100 nM
Estimate against measurement, compound 4: 9.1-fold (0.96 log units) below, outside the stated range (above it).
By their numbers in this assay, from the lowest: compound 3; then compounds 1 and 2 (each within the scatter of the next); then compound 4.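

In this assay, the position that tolerated chloro in place of hydrogen (a 1.3-fold higher number from compound 1 to compound 2 (0.13 log units; within the scatter)) proves sensitive to the choice of halogen once methyl sits on the other ring, with an 11-fold higher number from compound 3 to compound 4 (1.05 log units; beyond the scatter) for fluoro in place of chloro. With fluoro held on one ring, methyl on the other ring also gives a higher number whether it replaces chloro (a 2.5-fold higher number from compound 2 to compound 4 (0.39 log units; beyond the scatter)) or hydrogen (a 3.3-fold higher number from compound 1 to compound 4 (0.52 log units; beyond the scatter)), so compound 4 lies beyond the scatter from all three earlier compounds. Among these compounds, the small first step therefore did not describe this position in general: the effect of a change there differs between these pairs, although no pair shows the same change with both partner groups.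

No measurement shown accounts for the gap between chloro and fluoro at this position. The compounds shown leave open whether the chloro-to-fluoro step would be as large without methyl on the other ring, and whether bromo, methoxy or an amine at this position would give a number nearer that of compound 3 or that of compound 4.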